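A few compounds are considered here, and "the series" means these few. Any claim that something is new, unique, unknown or untested is made for them only; others in the source may bear on it.

Compound 1 `Nc1ccc(-c2cc(=O)c3c(N)c(F)cc(F)c3o2)cc1F` and compound 2 `CCC(=O)OCc1c(F)c(N)c2c(=O)cc(-c3ccc(N)c(F)c3)oc2c1F` share one core and differ in a single spot. In a functional assay on HeLa cells (Homo sapiens) for cytotoxicity, read by neutral red uptake, with a stated time of 3 days (on this read-out lower numbers stand for stronger inhibition and higher numbers for weaker inhibition), compound 1 gives > 100000 nM, which is a limit of the assay and not a number. In this assay compound 2 gives 69000 nM, the only plain number shown in this set. The step of an at least 1.4-fold lower number from compound 1 to compound 2 (0.16 log units; that floor lies within the scatter) connects them, and its floor comes from the limit of > 100000 nM in this assay, at which 1 of the 2 values shown sits, rather than from a measured pair of numbers. Compound 3 `CCCCCC(=O)OCc1c(F)c(N)c2c(=O)cc(-c3ccc(N)c(F)c3)oc2c1F` is not yet measured; it differs from compound 2 by propyl in place of hydrogen on a saturated chain carbon, two bonds along the chain from a carbonyl carbon. Among the measured compounds shown here, the only measured step bearing on it is the one between the first two compounds, and since that step rests on a limit, it sets no firm size or direction. For compound 3 the step of a 1.4-fold lower number from compound 2 to compound 3 (0.14 log units; within the scatter) is expected, a change not beyond the usual scatter. Compound 3 is therefore estimated at 50000 nM, in a range from 15000 nM to 150000 nM.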

Compound 3, half-maximal inhibitory concentration: 34000 nM
The estimate for compound 3 lay 1.5-fold (0.17 log units) above the measured number; the range from low to high includes it.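

In this assay there is a 2.0-fold lower number from compound 2 to compound 3 (0.31 log units; beyond the scatter), so this change, propanoyl to pentylcarbonyl at the end of the side group, has a modest effect on the number. Unlike the earlier step, this one rests on two plain numbers, which gives it a firm size and direction. There is also an at least 2.9-fold lower number from compound 1 to compound 3 (0.46 log units; beyond the scatter), which clears the scatter as the earlier floor did not, yet it is still only a floor, and it stems from compound 1, whose value is a limit of the assay: the limit of > 100000 nM in this assay, at which 1 of the 3 values shown sits.

A single step cannot show whether the number keeps falling with a longer chain such as octanoyl or turns back up. On these data alone, it also remains open what a branched chain, a benzoyl group or a chain ending in an amine would do at this position.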